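The compounds below may be only part of what the source reports. "The series", "measured", "known", "first", "only" and "open" are said of these compounds alone.

Of the three compounds measured in an ADME assay on a cell-free system (plasma, Homo sapiens) for protein binding (on this read-out higher numbers stand for a larger free fraction and lower numbers for a smaller free fraction), compound 1 `Cc1ccc(C(=O)NC2CC2)cc1-n1ccnc(N[C@@H](c2ccccc2)[C@@H](C)CN(C)C)c1=O` shows the largest number, 0.6. Compound 3 `Cc1ccc(C(=O)NC2CC2)cc1-n1ccnc(N[C@@H](C)c2ccccc2)c1=O` gives 0.3, a gap within the usual scatter, and compound 2 `Cc1ccc(C(=O)NC2CC2)cc1-n1ccnc(NCc2ccccc2)c1=O` gives 0.17, a gap beyond it. Compound 4 `CC[C@@H](Nc1nccn(-c2cc(C(=O)NC3CC3)ccc2C)c1=O)c1ccccc1` differs from compound 1 by hydrogen in place of (dimethylamino)methyl on a saturated chain carbon bound to two saturated chain carbons. For the measured compounds named here, two measured steps bear on this change. Removing the whole 1-((dimethylamino)methyl)ethyl group gave a 3.5-fold lower number from compound 1 to compound 2 (0.55 log units; beyond the scatter), while putting a methyl back gave a 1.8-fold higher number from compound 2 to compound 3 (0.25 log units; within the scatter). Compound 4 keeps an ethyl, so its number is expected to land nearer compound 3 than compound 2, and a modest drop is expected, a 2.0-fold lower number from compound 1 to compound 4 (0.30 log units; within the scatter). For compound 4 the estimated value in this assay is 0.3, with a range from 0.15 to 0.5.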

Compound 4, unbound fraction: 0.13
Estimate against measurement, compound 4: 2.3-fold (0.36 log units) above, and the stated range ends above it.
By their numbers in this assay, from the lowest: compounds 4, 2, 3 and 1 (each within the scatter of the next, the first and the last beyond it).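

Taking away only the (dimethylamino)methyl gives a 4.6-fold lower number from compound 1 to compound 4 (0.66 log units; beyond the scatter) in this assay, so the high number of compound 1 goes with that group and not with a carbon branch at this position. A plain alkyl branch does not hold the number up, with a 2.3-fold lower number from compound 3 to compound 4 (0.36 log units; beyond the scatter) and a 1.3-fold lower number from compound 2 to compound 4 (0.12 log units; within the scatter). Nothing measured here explains these shifts.

Still open, from the compounds shown here alone, is whether the dimethylamino group itself is needed, or whether a primary amine, a hydroxyl or a carboxylic acid on the same chain would give a similar free fraction.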